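Aryl variation on a fluorinated amide series

The source may report more compounds than this note shows. Statements on the series, on what has been measured and on what is new or still open speak of the compounds shown alone.

Two members of this series have been run in a functional assay on NCI-H460 cells (Homo sapiens) for cytotoxicity, read by MTT assay, with a stated time of 72 h; on this read-out lower numbers stand for stronger inhibition and higher numbers for weaker inhibition. Compound 1 `COc1cc2c(Oc3ccc(NC(=O)c4cc(-c5ccccc5F)ccn4)cc3F)ccnc2cc1OCCCN1CCCCC1` gives 130 nM in this assay. Compound 2 `COc1cc2c(Oc3ccc(NC(=O)c4cc(-c5ccc(C)cc5)ccn4)cc3F)ccnc2cc1OCCCN1CCCC1` gives 160 nM in this assay, the higher of the two numbers, with compound 1 as its nearest neighbour at a gap that sits inside the scatter of the method, so no order between the two can be read from these data.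

Compound 3 `COc1cc2c(Oc3ccc(NC(=O)c4cc(-c5ccccc5F)ccn4)cc3F)ccnc2cc1OCCCN1CCCC1` is the next compound, not yet measured. Compared with compound 2 the change is 2-fluorophenyl in place of 4-methylphenyl on an aromatic carbon. The 2-fluorophenyl group that enters is the same group carried by compound 1, and the two measured compounds, one with each aryl group, sit within the scatter of each other in this assay. Among the compounds with values here, no step between measured compounds isolates this change, so nothing beyond the scatter is expected from it.

The expected step from compound 2 to compound 3 is therefore a 1.1-fold lower number from compound 2 to compound 3 (0.06 log units; within the scatter) in this assay. Compound 3 is estimated at 140 nM, with a range from 60 nM to 330 nM, in this assay.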

Compound 3, half-maximal inhibitory concentration: 140 nM
The estimate for compound 3 equals the measured number at the digits printed; the range from low to high includes it.
By their numbers in this assay, from the lowest: compounds 1, 3 and 2 (each within the scatter of the next).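

Working notes: at the aromatic carbon opposite the ring nitrogen, this assay now has a direct one-place comparison, and putting 2-fluorophenyl in place of 4-methylphenyl gives a 1.1-fold lower number from compound 2 to compound 3 (0.06 log units; within the scatter), so these two aryl groups cannot be told apart on this read-out when the chain ends in pyrrolidin-1-yl. The same compound also gives the series its first one-place comparison at the chain end, where pyrrolidin-1-yl in place of piperidin-1-yl, on the saturated chain carbon three bonds along the chain from an oxygen on an aromatic ring, gives a 1.1-fold higher number from compound 1 to compound 3 (0.03 log units; within the scatter), so these two cyclic amines cannot be told apart either when the aryl group is 2-fluorophenyl. No accompanying measurement helps to interpret either comparison.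

The compounds shown leave open whether a group of another kind at the aryl position, such as a pyridyl ring or a phenyl ring carrying a carboxylic acid, would separate from these values in this assay. At the chain end, the same question stands for morpholin-4-yl, dimethylamino or a longer chain, and for whether the two positions act independently, which would take the 4-methylphenyl and piperidin-1-yl pairing.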